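The compounds below may be only part of what the source reports. "The series", "measured", "known", "first", "only" and "open" are said of these compounds alone.

Measured compounds in a functional assay on DU-145 cells (Homo sapiens) for cytotoxicity; a lower number here means a stronger inhibitor, a higher number a weaker inhibitor:

Compound 1 `C=CCC/C=C\C=C/CCCCCCCC[C@H]1CC[C@H]([C@@H]2CC[C@@H](CC(=O)O)OO2)O1` gives 0.1 ug/mL.
Compound 2 `C=CCCC/C=C/C=C\CCCCCCCC[C@H]1CC[C@H]([C@@H]2CC[C@@H](CC(=O)O)OO2)O1` gives 0.1 ug/mL.
Compound 3 `C=CCCC/C=C/C=C\CCCCCCCC[C@H]1CC[C@H]([C@@H]2CC[C@@H](CC(=O)OC)OO2)O1` gives 0.1 ug/mL.

All three sit level in this assay. Compound 2 differs from compound 1 by a group of 6 heavy atoms (6 carbon; no ring) in place of a group of 7 heavy atoms (7 carbon; no ring), on a double-bonded chain carbon bound to a double-bonded chain carbon; this step made no change at the digits printed from compound 2 to compound 1 (within the scatter). Compound 2 differs from compound 3 by methyl in place of hydrogen on an oxygen next to a carbonyl group; that step made no change at the digits printed from compound 2 to compound 3 (within the scatter). Going by the values given here, compound 3 and compound 1 have no step between them beyond what their two values show, and those values are the same at the digits given.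

Compound 4 `C=CCC/C=C\C=C/CCCCCCCC[C@H]1CC[C@H]([C@@H]2CC[C@@H](CC(=O)OC)OO2)O1` has not yet been measured in this assay. Relative to compound 3 it shows (a group of 6 heavy atoms (6 carbon; no ring) in place of a group of 7 heavy atoms (7 carbon; no ring), on a double-bonded chain carbon bound to a double-bonded chain carbon). This is the same change as that made from compound 2 to compound 1, the place being the same word for word; the two cores differ by methyl in place of hydrogen on an oxygen next to a carbonyl group, the methyl ester in place of the free acid. Because no change at the digits printed from compound 2 to compound 1 (within the scatter) was flat, and because no change at the digits printed from compound 2 to compound 3 (within the scatter) was flat as well, the expected step is no change at the digits printed from compound 3 to compound 4 (within the scatter), with no sign from the series that the chain change depends on the acid or ester. Compound 4 is therefore estimated at 0.1 ug/mL, expected to fall between 0.05 ug/mL and 0.2 ug/mL.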

Compound 4, half-maximal inhibitory concentration: 0.1 ug/mL
Beside the measured number, compound 4's estimate shows no gap at the digits printed, and the stated range covers the measured number.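

Within this assay, the group of 6 heavy atoms in place of hepta-1,6-dien-1-yl gives no change at the digits printed from compound 3 to compound 4 (within the scatter) on the methyl ester core, and this agrees with the same change on the free acid core: the same change on two cores in this assay, no change at the digits printed (within the scatter) from compound 2 to compound 1 and no change at the digits printed (within the scatter) from compound 3 to compound 4, 1.0-fold (0.00 log units) apart, within the scatter of two such steps.
The methyl ester in place of the free acid gives no change at the digits printed from compound 1 to compound 4 (within the scatter) and likewise reads the same on both chains: the same change on two cores in this assay, no change at the digits printed (within the scatter) from compound 2 to compound 3 and no change at the digits printed (within the scatter) from compound 1 to compound 4, 1.0-fold (0.00 log units) apart, within the scatter of two such steps.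
Each change therefore carries between these two cores without any visible dependence on the other, but all four steps are flat, so this shows only that two null results agree and does not show that a step with a measurable effect would carry over or add up in this series.

The compounds shown leave open whether the level reading holds for a fully saturated chain or a much longer chain. They also leave open whether it holds for an amide or a primary alcohol in place of the free acid and methyl ester.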